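The source may hold more compounds than are shown below. What is called first, only, known or untested is meant among the compounds shown, and "the series" means these compounds.

Working notes on the series. Compound 1 `Nc1cc(N)c2nc(-c3ccccc3)c(Oc3ccc(Cl)c(Cl)c3)nc2c1` is the reference point of the set. Among the compounds with values here, in a functional assay on IGROV-1 cells (Homo sapiens) for inhibition, read by sulforhodamine B assay, with a stated time of 48 h (on this read-out higher numbers stand for weaker inhibition of growth and lower numbers for stronger inhibition of growth), compound 1 gives 32400 nM, the only numerical value among the three measured compounds. Compound 2 `CCOC(=O)[C@H](CCC(=O)O)NC(=O)c1ccc(CNc2nc3cc(N)cc(N)c3nc2-c2ccccc2)cc1` reaches only a limit of the assay, < 100000 nM. Compound 3 `CCOC(=O)[C@H](CCC(=O)O)NC(=O)c1ccc(Sc2nc3cc(N)cc(N)c3nc2-c2ccccc2)cc1` likewise returns a limit rather than a number, < 100000 nM. Beyond compound 1 the only anchor is the limit of < 100000 nM in this assay, at which 2 of the 3 values shown sit, which fixes no direction for any step. Compound 4 `Nc1cc(N)c2nc(-c3ccccc3)c(Sc3ccc(F)cc3)nc2c1` carries (4-fluorophenyl)sulfanyl in place of 3,4-dichlorophenoxy on an aromatic carbon. Within the data shown here, no measured step bears on this change, so the step from compound 1 to compound 4 in this assay is expected to be a 1.2-fold higher number from compound 1 to compound 4 (0.09 log units; within the scatter), nothing beyond the scatter. Compound 4 is estimated at 40000 nM, between 10000 nM and 100000 nM.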

Compound 4, concentration for total growth inhibition: < 100000 nM
Compound 4 gave a limit, no number (the forecaster's own chance of this, stated with the estimate: 30%); the middle value does not contradict the limit.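

In this assay, within the data shown here, compound 4 returns only the limit < 100000 nM and not a number, so no step from compound 1 to compound 4 can be read. Whether (4-fluorophenyl)sulfanyl in place of 3,4-dichlorophenoxy changes growth inhibition at all stays open: the limit of < 100000 nM in this assay, at which 3 of the 4 values shown sit.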